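Swapping the halogenated ring for pyridin-2-yl

The source may hold more compounds than are shown below. What is called first, only, known or untested is meant among the compounds shown, and "the series" means these compounds.

Compound 3 `Cc1ccc2c(c1)/C(=N/NC(=S)N/N=C/c1ccccc1Br)C(=O)N2` was tested in a functional assay on COS-7 cells (Chlorocebus aethiops) for inhibition, read by MTT assay; a higher number here means a weaker inhibitor, a lower number a stronger inhibitor. For compound 3 this assay reports only a limit, > 50000 nM, and not a number. Compound 1 `COc1ccc(/C=N/NC(=S)N/N=C2\C(=O)Nc3ccc(C)cc32)cc1O` gives 3190 nM, and compound 2 `Cc1ccc2c(c1)/C(=N/NC(=S)N/N=C/c1c(Cl)cccc1Cl)C(=O)N2` gives 3870 nM. The step of an at least 15-fold higher number from compound 1 to compound 3 (1.19 log units; beyond the scatter) and the step of an at least 12-fold higher number from compound 2 to compound 3 (1.11 log units; beyond the scatter) show that the 2-bromophenyl arm sits far above both other arms, while a 1.2-fold higher number from compound 1 to compound 2 (0.08 log units; within the scatter) stays within the scatter. Compound 4 `Cc1ccc2c(c1)/C(=N/NC(=S)N/N=C/c1ccccn1)C(=O)N2` carries the change (pyridin-2-yl in place of 2-bromophenyl on a carbon with a double bond to nitrogen). For the measured compounds named here, no measured step involves pyridin-2-yl, so its own effect is unknown; both measured steps onto compound 3 were large losses, so moving away from the 2-bromophenyl arm may recover part of that. Compound 4 is therefore expected near 15000 nM, between 4000 nM and 60000 nM, a step of an at least 3.3-fold lower number from compound 3 to compound 4 (0.52 log units; beyond the scatter).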

Compound 4, half-maximal inhibitory concentration: 2120 nM
Compound 4: the middle estimate sits 7.1-fold (0.85 log units) above what was measured; measured number outside the range, below it.
By their numbers in this assay, from the lowest: compounds 4, 1 and 2 (each within the scatter of the next). At a limit, above all of these: compound 3.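

Replacing 2-bromophenyl with pyridin-2-yl on this carbon brings an at least 23-fold lower number from compound 3 to compound 4 (1.37 log units; beyond the scatter), so the steep loss belongs to the 2-bromophenyl arm and not to every arm placed here. Pyridin-2-yl also stays level with the other two arms, with a 1.8-fold lower number from compound 2 to compound 4 (0.26 log units; within the scatter) and a 1.5-fold lower number from compound 1 to compound 4 (0.18 log units; within the scatter), which leaves 2-bromophenyl alone standing apart. The value of compound 3 is only a limit, so its step is a minimum: the limit of > 50000 nM in this assay, at which 1 of the 4 values shown sits.

Still open, on these data alone, is whether the recovery comes from the ring nitrogen or simply from losing the bromine. A plain phenyl, 2-chlorophenyl or pyridin-4-yl arm could separate these two readings.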